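A few compounds are considered here, and "the series" means these few. Any claim that something is new, unique, unknown or untested is made for them only; others in the source may bear on it.

Measured compounds:
Compound 1, `O=C(/C=C/c1ccccc1)c1ccc(N2CCN(c3cccc(Cl)c3Cl)CC2)cc1`, gives 30.7%.
Compound 2, `COc1ccc(/C=C/C(=O)c2ccc(N3CCN(c4ccc(Cl)c(Cl)c4)CC3)cc2)cc1OC`, gives 63.5%.

Both numbers come from a functional assay on the whole organism (strain Kunming) for inhibition, with Mus musculus as the target, with a stated time of 1 h, at a dose of 40 mg/kg by the oral route; on this read-out lower numbers stand for less inhibition and higher numbers for more inhibition at the one dose given (going by the name of the read-out). Of the two measured compounds, compound 1 stands lowest; the nearest, compound 2, lies higher by a gap beyond the usual scatter. Among the measured compounds shown here, compound 1 and compound 2 differ in more than one place, so no single step connects them, and their two values say only that much.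

The unmeasured compound 3, `O=C(/C=C/c1ccccc1)c1ccc(N2CCN(S(=O)(=O)c3ccccc3)CC2)cc1`, departs from compound 1 by one change: phenylsulfonyl in place of 2,3-dichlorophenyl on an amine nitrogen in a ring. For the measured compounds named here, no step between measured compounds shows what such a change does in this assay, so any expectation rests on the value of compound 1 alone. Since compound 1 itself gives 30.7% in this assay, compound 3 is expected to sit near it, with the step of a number 3.7 percentage points lower from compound 1 to compound 3 (within the scatter) estimated to fall within the scatter, leaning slightly downward. Compound 3 is therefore estimated at 27%, with a range from 8% to 48%.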

Compound 3, a percentage reported as inhibition, in the whole organism at one dose (the size of the read-out at that dose, not a potency): 30%
Compound 3: the middle estimate sits 3 percentage points below what was measured; low and high end bracket the measured number.
By their numbers in this assay, from the lowest: compounds 3 and 1 (each within the scatter of the next); then compound 2.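

In this assay, among the compounds shown here, phenylsulfonyl in place of 2,3-dichlorophenyl on the amine nitrogen in the ring gives a number 0.7 percentage points lower from compound 1 to compound 3 (within the scatter) and is the first step at this position that can be read. The two groups therefore cannot be told apart by this read-out at the one dose given, even though the change removes both chlorine atoms and brings in a sulfur atom, two oxygen atoms and hydrogen-bond acceptors absent from the group that leaves. This position thus accepts two quite different groups with no difference beyond the scatter, but that finding rests on a single step, and nothing measured here speaks to why the two groups read alike.

The compounds shown leave open whether this holds for other groups on the same nitrogen, such as a benzoyl, a benzyl or a methanesulfonyl group, or for a bare amine hydrogen there. For the compounds shown here, they also leave open which of its several differences goes with the higher value of compound 2, as no single step links it to compound 1 or compound 3.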